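The source may hold more compounds than are shown below. What is called first, only, known or untested is meant among the compounds shown, and "the series" means these compounds.

Of the compounds shown here, three of a shared core have been measured in an ADME assay on a cell-free system (plasma, Mus musculus) for protein binding, using equilibrium dialysis. Compound 1 `CC(C)c1csc(-c2cccc(CN(C)c3ccc4[nH]nc(C(=O)O)c4c3)c2O)n1` reaches the limit of the assay, > 99.9%, which gives no number but only a bound (the limit of > 99.9% in this assay, at which 1 of the 3 values shown sits). Compound 3 `CN(C)c1noc(-c2cccc(CN(C)c3ccc4[nH]nc(C(=O)O)c4c3)c2O)n1` gives 99.9%. Between them stands the step an unbound fraction no lower from compound 1 to compound 3 (the limit leaves the size open), whose size the limit leaves open. Compound 2 `Cc1nc(-c2cccc(CNc3ccc4[nH]nc(C(=O)O)c4c3)c2O)sc1C` also sits at a limit of the assay, > 99.8%, so that only a bound and no number is known for it (the limit of > 99.8% in this assay, at which 1 of the 3 values shown sits).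

Compound 4 `CC(C)c1coc(-c2cccc(CNc3ccc4[nH]nc(C(=O)O)c4c3)c2O)n1` is yet to be measured. It differs from compound 2 in one place: 4-isopropyl-1,3-oxazol-2-yl in place of 4,5-dimethyl-1,3-thiazol-2-yl on an aromatic carbon. Going by the values given here, the only measured step that bears on this change is the ring swap on the same aromatic carbon from compound 1 to compound 3, and that step is of unreadable size. Among the compounds with values here, nothing among the measured values points to a shift beyond the scatter, and the estimate for compound 4 therefore rests on the bound for compound 2, expected as a step that the limit leaves unreadable from compound 2 to compound 4. Compound 4 is thus expected to give about 99.85% in this assay, with a range from 99.3% to 99.97%.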

Compound 4, plasma protein binding: > 99.7%
Compound 4 ended at the assay's limit; the forecaster's own chance of this, stated with the estimate: 60%; the middle value lies beyond the limit too.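

In this assay compound 4 gives > 99.7%, a limit and not a number. Compound 2 also stands at a limit, and no step can be read between compound 2 and compound 4. The compounds shown leave open whether 4-isopropyl-1,3-oxazol-2-yl in place of 4,5-dimethyl-1,3-thiazol-2-yl changes plasma protein binding at all.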